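Heteroaryl for aryl on the shared core: working notes

This account rests on a few compounds, and the source may have more. Where it says the series, first, only, none or still open, it means among the compounds named here.

Measured so far:
- compound 1 `COc1cccc(Oc2c(NS(=O)(=O)c3ccc(C(C)(C)C)cc3)ncnc2OCCOc2ncc(Br)cn2)c1`: 0.051 nM
- compound 2 `CCc1ccc(-c2c(NS(=O)(=O)c3ccc(C(C)(C)C)cc3)ncnc2OCCOc2ncc(SC)cn2)cc1`: 0.013 nM

In an assay on cells (Endothelial cell) for binding affinity to Endothelin-1 receptor (Sus scrofa) (on this read-out higher numbers stand for weaker inhibition and lower numbers for stronger inhibition), compound 2 gives 0.013 nM, the lowest of the two numbers to hand. Compound 1 gives 0.051 nM in this assay, a higher number, and the gap between the two lies beyond the usual scatter. Compound 1 and compound 2 differ in more than one place, so nothing is read from their pair beyond what the two values show.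

Compound 3 `CSc1cnc(OCCOc2ncnc(NS(=O)(=O)c3ccc(C(C)(C)C)cc3)c2-c2ccc(C)s2)nc1` has not yet been measured. Compared with compound 2 the change is 5-methylthiophen-2-yl in place of 4-ethylphenyl on an aromatic carbon of a six-membered aromatic ring with 2 nitrogen, ortho to a 2-((5-(methylsulfanyl)pyrimidin-2-yl)oxy)ethoxy group, ortho to a large group, two atoms from the ring nitrogen. The rest of compound 2 is kept. Within the data shown here, no measured pair isolates this change, so the expectation rests on the size of the entering group being close to that of the leaving one and on the number compound 2 gives, 0.013 nM. The step from compound 2 to compound 3 is expected to be small, a 1.5-fold higher number from compound 2 to compound 3 (0.19 log units; within the scatter), with no clear direction beyond the scatter. Compound 3 is estimated at 0.02 nM in this assay, within 0.006 nM to 0.07 nM.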

Compound 3, half-maximal inhibitory concentration: 0.16 nM
Estimate against measurement, compound 3: 8.0-fold (0.90 log units) below; measured number above the stated range.
By their numbers in this assay, from the lowest: compound 2; then compound 1; then compound 3.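

The position on an aromatic carbon of a six-membered aromatic ring with 2 nitrogen is not indifferent to which aromatic group it carries: in this assay, 5-methylthiophen-2-yl in place of 4-ethylphenyl gives a 12-fold higher number from compound 2 to compound 3 (1.09 log units; beyond the scatter), a large step towards weaker inhibition. Among these compounds, this is the first change that can be read at a single place, as compound 1 and compound 2 differ in more than one place and their pair gave no reading for any one group. Nothing at hand accounts for the size of this step.

The change replaces the ring and its alkyl substituent together, so the compounds shown leave open how much of the step belongs to the thiophene ring and how much to methyl standing where ethyl stood; a 4-methylphenyl or a 5-ethylthiophen-2-yl group at this place would separate the two. Also open, as far as these compounds go, is whether an unsubstituted thiophen-2-yl or a ring bearing an amine would follow compound 3 or stay closer to compound 2.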